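The source may report more compounds than this note shows. Statements on the series, on what has been measured and on what is new or still open speak of the compounds shown alone.

Measured in a functional assay on MCF7 cells (Homo sapiens) for inhibition, read by sulforhodamine B assay; on this read-out higher numbers stand for weaker inhibition of growth and lower numbers for stronger inhibition of growth:
Compound 1 `COc1cc(-c2ccc(-c3ccc(-c4nc5cc(C)ccc5[nH]4)cc3)cc2)cc(OC)c1OC`: 170 nM
Compound 2 `COc1cc(-c2ccc(-c3ccc(-c4nc5ccccc5[nH]4)cc3)cc2)cc(OC)c1OC`: 6380 nM
Compound 3 `COc1ccc(-c2ccc(-c3ccc(-c4nc5c(O)cccc5[nH]4)cc3)cc2)cc1OC`: 190 nM

Compound 3, at 190 nM, lies within the usual scatter of compound 1 and far under compound 2, the highest number of the three. Compound 4 `COc1cc(-c2ccc(-c3ccc(-c4nc5c(O)cccc5[nH]4)cc3)cc2)cc(OC)c1OC` has methoxy in place of hydrogen on an aromatic carbon. Going by the values given here, no measured step makes this exchange. The only one, a different exchange, is large: a 38-fold higher number from compound 1 to compound 2 (1.57 log units; beyond the scatter). It shows that one small change can matter here, but it gives no direction for this one. So no shift beyond the scatter is expected in this assay, though with real uncertainty. The expected step is a 1.1-fold higher number from compound 3 to compound 4 (0.02 log units; within the scatter). For compound 4 the estimated value is 200 nM, with an expected range of 60 nM to 800 nM.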

Compound 4, concentration for 50% growth inhibition: < 100 nM
Compound 4: a limit, no number (the forecaster's own chance of this, stated with the estimate: 3%); at least 2.0-fold (0.30 log units) between middle value and limit.
By their numbers in this assay, from the lowest: compounds 1 and 3 (each within the scatter of the next); then compound 2. At a limit, below all of these: compound 4.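

Compound 4 is recorded only as a limit in this assay: the limit of < 100 nM in this assay, at which 1 of the 4 values shown sits. The added methoxy gives an at least 1.9-fold lower number from compound 3 to compound 4 (0.27 log units; that floor lies within the scatter), and the exchange of ring groups gives an at least 1.7-fold lower number from compound 1 to compound 4 (0.23 log units; that floor lies within the scatter); these two steps cannot be read as real changes, though the methoxy does not raise the number. Hydroxy in place of hydrogen gives an at least 63-fold lower number from compound 2 to compound 4 (1.80 log units; beyond the scatter), so hydroxy joins methyl as a group whose presence goes with a large drop from compound 2.

From the compounds shown here alone, whether an amine or a carboxylic acid in place of that hydroxy would keep the number this low stays open. So does the true value of compound 4.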